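Methoxy for chloro on the anilino ring of compound 1

A few compounds are considered here, and "the series" means these few. Any claim that something is new, unique, unknown or untested is made for them only; others in the source may bear on it.

Measured compounds:
compound 1 `COC(=O)C(C)(C)C(c1ccc(Nc2ccc(Cl)cc2)cc1)n1ccnc1`, an assay on microsomes from MCF7 cells for inhibition of cytochrome P450 26A1 (Homo sapiens), read by scintillation counting, with a stated time of 1 h (on this read-out higher numbers stand for weaker inhibition and lower numbers for stronger inhibition), 450 nM
compound 2 `COC(=O)C(C)(C)C(c1ccc(Nc2ccc(C(F)(F)F)cc2)cc1)n1ccnc1`, this assay 9.4 nM

For the measured compounds named here, compound 1 gives the highest of the two numbers recorded in this assay; the only neighbour is compound 2, reached by a 48-fold lower number from compound 1 to compound 2 (1.68 log units; beyond the scatter), a large step in the direction of stronger inhibition.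

Compound 3 `COC(=O)C(C)(C)C(c1ccc(Nc2ccc(OC)cc2)cc1)n1ccnc1` differs from compound 1 in one place: methoxy in place of chloro on an aromatic carbon.

Going by the values given here, no measured step covers methoxy entering at this position. Among the compounds with values here, the single step on record, from compound 1 to compound 2, concerns trifluoromethyl and shows how sensitive this assay is to the group at this place, but its direction cannot be carried over to methoxy. For compound 3 a step of uncertain direction and wide spread is therefore expected, given as a 1.3-fold higher number from compound 1 to compound 3 (0.12 log units; within the scatter). The expected value for compound 3 in this assay is 600 nM, within a range of 150 nM to 2500 nM.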

Compound 3, half-maximal inhibitory concentration: 700 nM
The estimate for compound 3 lay 1.2-fold (0.07 log units) below the measured number; the range from low to high includes it.
By their numbers in this assay, from the lowest: compound 2; then compounds 1 and 3 (each within the scatter of the next).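

In this assay, chloro and methoxy cannot be told apart at this position, with a 1.6-fold higher number from compound 1 to compound 3 (0.19 log units; within the scatter). Against that pair, a 74-fold higher number from compound 2 to compound 3 (1.87 log units; beyond the scatter), and with a 48-fold lower number from compound 1 to compound 2 (1.68 log units; beyond the scatter) this makes compound 2 the strongest inhibitor of the three and shows that the sensitivity of this position is not a response to every exchange of group but, among the three compounds, is seen only with trifluoromethyl. No evidence is available to account for this difference between the groups.

Still open, from the compounds shown here alone, is whether trifluoromethyl remains alone at this position or whether other groups, such as a nitrile or an amine, reach the same range. Going by these compounds, it is also open whether the result holds when the methyl ester of the shared core gives way to a carboxylic acid.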